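Swapping a Hexyl Thioether for a Chlorobenzyl Thioether

The source may hold more compounds than are shown below. What is called first, only, known or untested is meant among the compounds shown, and "the series" means these compounds.

Measured so far:
compound 1, `CCSc1n[nH]c(-n2[se]c3ccccc3c2=O)n1`: 35200 nM
compound 2, `CCCCCCSc1n[nH]c(-n2[se]c3ccccc3c2=O)n1`: 39300 nM

Of the compounds shown here, two sharing one core have been measured in an ADME assay on L929 cells (Mus musculus) for antiproliferative activity, read by CCK-8 assay, with a stated time of 48 h; on this read-out lower numbers stand for stronger inhibition and higher numbers for weaker inhibition. Compound 1 gives 35200 nM in this assay. For the measured compounds named here, compound 2 gives 39300 nM in this assay, and the only measured step, a 1.1-fold higher number from compound 1 to compound 2 (0.05 log units; within the scatter), places the two values within the scatter of each other, so compound 2 stands in this assay at the same level as its only neighbour, compound 1.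

The next compound, compound 3, `O=c1c2ccccc2[se]n1-c1nc(SCc2ccc(Cl)cc2)n[nH]1`, is the step from compound 2 in which (4-chlorophenyl in place of pentyl on a saturated chain carbon bound to a sulfur). Going by the values given here, no measured step bears directly on this change: the one step on record, a 1.1-fold higher number from compound 1 to compound 2 (0.05 log units; within the scatter), changes only the length of the chain and stays within the scatter, whereas compound 3 introduces an aromatic ring with a chlorine. With nothing in the data pointing either way, the expectation for compound 3 in this assay is a step of a 1.2-fold lower number from compound 2 to compound 3 (0.09 log units; within the scatter), no larger than the scatter, and the estimated value for compound 3 is 32000 nM, with a range from 10000 nM to 100000 nM.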

Compound 3, half-maximal inhibitory concentration: 39500 nM
Estimate against measurement, compound 3: 1.2-fold (0.09 log units) below, and the stated range covers the measured number.
By their numbers in this assay, from the lowest: compounds 1, 2 and 3 (each within the scatter of the next).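

In this assay the swap of hexyl for 4-chlorobenzyl on the sulfur shows no change beyond the scatter (a 1.0-fold higher number from compound 2 to compound 3 (0.00 log units; within the scatter)), and the comparison of compound 1 with compound 3 reads the same way (a 1.1-fold higher number from compound 1 to compound 3 (0.05 log units; within the scatter)). The earlier pair spoke only to the length of a saturated chain, whereas these steps bring in a six-membered aromatic ring carrying a chlorine, and the three compounds still stand at one level in this assay, so at this place neither a longer chain nor this ring separates them. Nothing on hand gives a reason for this flat result.

The compounds shown do not tell whether the chlorine plays any part, since a plain benzyl group does not appear among them, and a single ring substituent cannot speak for others such as a methoxy group or a nitrile. They also leave open whether a quite different group on the sulfur chain, such as an amine or a carboxylic acid, would carry the number beyond the scatter in either direction.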